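Propargylsulfanyl in place of 3-bromobenzylsulfanyl on the shared core

This account rests on a few compounds, and the source may have more. Where it says the series, first, only, none or still open, it means among the compounds named here.

This account follows a series of pyrazole-amine compounds tested in a functional assay on PC-9 cells (Homo sapiens) for inhibition, read by MTT assay, with a stated time of 72 h; a lower number here means a stronger inhibitor, a higher number a weaker inhibitor. Compound 1 `Cc1cc(Nc2cc(-c3ccccc3)[nH]n2)n2nc(SCc3cccc(Br)c3)nc2n1` gives 8900 nM. Compound 2 `Cc1cc(Nc2ccn(Cc3nc(C)c4ccccc4n3)n2)n2nc(SCc3ccc(Br)cc3)nc2n1` gives 5450 nM, which sits within the scatter of the number for compound 1, so the two cannot be ranked against each other. Compound 3 `Cc1cc(Nc2ccn(Cc3ccccc3)n2)n2nc(SCc3ccc(Br)cc3)nc2n1` reaches only the limit of the assay, > 50000 nM, and so yields no number (the limit of > 50000 nM in this assay, at which 1 of the 3 values shown sits). For the measured compounds named here, the one measured step within this set, an at least 9.1-fold higher number from compound 2 to compound 3 (0.96 log units; beyond the scatter), concerns the group on the saturated chain carbon bound to an aromatic nitrogen and not the sulfur-bound side chain.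

Compound 4 `C#CCSc1nc2nc(C)cc(Nc3cc(-c4ccccc4)[nH]n3)n2n1` differs from compound 1 at the sulfur-bound chain: ethynyl in place of 3-bromophenyl on a saturated chain carbon bound to a sulfur. Going by the values given here, no measured step touches this position, so the direction of the change rests on no direct evidence; the loss of a six-membered aromatic ring, leaving only the small ethynyl group, is the whole of the change. Compound 4 is therefore expected to give a somewhat higher number than compound 1, with the step of a 1.8-fold higher number from compound 1 to compound 4 (0.25 log units; within the scatter) estimated to stay modest. Compound 4 is estimated at 16000 nM, within a range from 5000 nM to 50000 nM.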

Compound 4, half-maximal inhibitory concentration: > 50000 nM
Compound 4: only a limit was reported (the forecaster's own chance of this, stated with the estimate: 25%); at least 3.1-fold (0.49 log units) between middle value and limit.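

For the compounds shown here, the step at the sulfur-bound chain is the first measured one at this position: ethynyl in place of 3-bromophenyl on a saturated chain carbon bound to a sulfur gives an at least 5.6-fold higher number from compound 1 to compound 4 (0.74 log units; beyond the scatter), so in this assay this position is not indifferent to the change. Compound 4 gives > 50000 nM, which is a limit of the assay and not a number. The step is therefore a lower bound on the true size of the change, and the earlier compounds had placed a value at this limit only through a change at the other end of the molecule, on the carbon bound to an aromatic nitrogen, whereas the limit is now also reached through the sulfur-bound chain: the limit of > 50000 nM in this assay, at which 2 of the 4 values shown sit.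

With only 3-bromophenyl and ethynyl on this carbon, the compounds shown do not separate the part played by the bromine from that of the ring itself, and a plain phenyl, a longer chain or a chain ending in an amine or a carboxylic acid would each bear on that question. They also leave open whether the same change would give a step of like size on the structure of compound 2.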